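Alkoxy chain on the oxime oxygen: lipophilicity series

This account rests on a few compounds, and the source may have more. Where it says the series, first, only, none or still open, it means among the compounds named here.

Measured compounds:
compound 1 `CCO/N=C/c1c(N)ncnc1Oc1ccc(NC(=O)C2(C(=O)Nc3ccc(F)cc3)CC2)cc1F`: 3.41
compound 2 `Nc1ncnc(Oc2ccc(NC(=O)C3(C(=O)Nc4ccc(F)cc4)CC3)cc2F)c1/C=N/O`: 2.62
compound 3 `CCCCO/N=C/c1c(N)ncnc1Oc1ccc(NC(=O)C2(C(=O)Nc3ccc(F)cc3)CC2)cc1F`: 4.2

In a physicochemical assay for lipophilicity, using the shake flask method (on this read-out higher numbers stand for higher lipophilicity and lower numbers for lower lipophilicity), compound 2 gives 2.62, the lowest of the three; compound 1 and compound 3 lie above it, each beyond the scatter. The unmeasured compound 4 `COCCCO/N=C/c1c(N)ncnc1Oc1ccc(NC(=O)C2(C(=O)Nc3ccc(F)cc3)CC2)cc1F` differs from compound 2 by 3-methoxypropyl in place of hydrogen on an oxygen. The relevant steps are a number 0.79 log units lower from compound 1 to compound 2 (beyond the scatter), read in reverse, and a number 1.58 log units higher from compound 2 to compound 3 (beyond the scatter): each extra chain carbon on that oxygen raised this assay in the measured pairs. The entering group carries 5 heavy atoms, like butyl plus one hydrogen-bond acceptor, so a rise is expected for compound 4, plausibly smaller than the butyl step. The estimate for compound 4 is 3.4, range 3 to 3.9, meaning an expected step of a number 0.78 log units higher from compound 2 to compound 4 (beyond the scatter).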

Compound 4, partition coefficient: 3.18
Estimate against measurement, compound 4: 0.22 log units above, and the stated range covers the measured number.
By their numbers in this assay, from the lowest: compound 2; then compounds 4 and 1 (each within the scatter of the next); then compound 3.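

At this oxygen, chain length alone does not set the reading in this assay: methoxy in place of methyl at the chain end gives a number 1.02 log units lower from compound 3 to compound 4 (beyond the scatter). 3-methoxypropyl in place of hydrogen still gives a number 0.56 log units higher from compound 2 to compound 4 (beyond the scatter), but the longer chain of compound 4 is not separated from the ethyl chain, a number 0.23 log units lower from compound 1 to compound 4 (within the scatter), so compound 4 goes against the rise seen from compound 1 to compound 3. Nothing available bears on the origin of these steps. Open, as far as these compounds go, is how 2-methoxyethyl, with its oxygen closer to the oxime, would read, and whether an amine or carboxylic acid at the chain end would follow methoxy.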